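Pentyl in place of 4-hydroxycyclohexyl on the shared amide

The source may hold more compounds than are shown below. What is called first, only, known or untested is meant among the compounds shown, and "the series" means these compounds.

In an ADME assay on MRC5 cells (Homo sapiens) for inhibition, with a stated time of 72 h (on this read-out lower numbers stand for an effect already at smaller amounts and higher numbers for an effect only at larger amounts of compound), compound 2 `COc1cccc(OC)c1C(=O)Nc1c[nH]nc1C(=O)N[C@H]1CC[C@H](O)CC1` gives 34000 nM, the higher of the two numbers at hand. Compound 1 `CCc1ccccc1C(=O)Nc1c[nH]nc1C(=O)N[C@H]1CC[C@H](OC)CC1` gives 3400 nM in this assay, a lower number by a margin beyond the scatter. Compound 3 `COc1cccc(OC)c1C(=O)Nc1c[nH]nc1C(=O)NC1CCN(C(=O)OC(C)(C)C)CC1` gives > 50000 nM in this assay, which is a limit of the assay and not a number. Compound 4 `CCCCCNC(=O)c1n[nH]cc1NC(=O)c1c(OC)cccc1OC` has not yet been measured in this assay; it differs from compound 2 by pentyl in place of 4-hydroxycyclohexyl on an amide-type nitrogen. Among the measured compounds shown here, no pair of measured compounds carries this same change, so its size has no precedent here; a step toward a lower number, of a size that may or may not exceed the scatter, is expected a 1.7-fold lower number from compound 2 to compound 4 (0.23 log units; within the scatter). Compound 4 is estimated at 20000 nM, within 6000 nM to 50000 nM, with a fair chance that this assay returns only a limit.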

Compound 4, half-maximal effective concentration: > 50000 nM
Compound 4: no number, only a limit; the forecaster's own chance of this, stated with the estimate: 30%; middle value at least 2.5-fold (0.39 log units) from the limit.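

In this assay, pentyl in place of 4-hydroxycyclohexyl on the amide-type nitrogen gives an at least 1.4-fold higher number from compound 2 to compound 4 (0.16 log units; that floor lies within the scatter). Among the compounds shown here, this is the first single change read at this position, and the open chain brings no move toward a lower number. The true size of the step cannot be read, because compound 4 gives only a limit of the assay and not a number: the limit of > 50000 nM in this assay, at which 2 of the 4 values shown sit.

As far as these compounds go, whether a shorter chain, or a chain ending in an amine or a carboxylic acid, would bring a lower number on this nitrogen stays open. Also open, from the compounds shown here alone, is how far the number of compound 4 lies past its limit.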